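The source may hold more compounds than are shown below. What is called first, only, known or untested is meant among the compounds shown, and "the series" means these compounds.

Measured so far:

- compound 1 `COc1cccc(CNC(=O)c2c([N+](=O)[O-])noc2-c2ccc([N+](=O)[O-])cc2)c1` in an ADME assay on J774.A1 cells (Mus musculus) for cytotoxicity, read by MTT assay, with a stated time of 48 h (on this read-out lower numbers stand for higher toxicity in this test and higher numbers for lower toxicity in this test), gives "not determined" (no result reported)
- compound 2 `O=C(Nc1ccccc1)c1c([N+](=O)[O-])noc1-c1ccc(Cl)cc1Cl` in this assay gives 67300 nM
- compound 3 `O=C(NCc1ccc(F)cc1)c1c([N+](=O)[O-])noc1-c1ccc(Cl)cc1Cl` in this assay gives 86400 nM

Only two of these compounds have a number to compare. Compound 3 stands level with compound 2, and the gap between them lies within the scatter of repeated measurements. Compound 1 has no number, so it cannot be placed.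

The next compound to be tested is compound 4 `COc1cccc(CNC(=O)c2c([N+](=O)[O-])noc2-c2ccc(Cl)cc2Cl)c1`, which shares the core of compound 3. The difference is 3-methoxyphenyl in place of 4-fluorophenyl on a saturated chain carbon bound to an amide-type nitrogen, or in words, 3-methoxyphenyl in place of 4-fluorophenyl on a saturated chain carbon bound to an amide-type nitrogen. Compound 1 carries the same 3-methoxybenzyl group, but without a number it offers no guide.

For the measured compounds named here, one measured step bears on this change, as it also alters the group on the amide-type nitrogen. That step is a 1.3-fold higher number from compound 2 to compound 3 (0.11 log units; within the scatter), and it came with 4-fluorobenzyl in place of phenyl. A single small step is thin evidence, but on that basis no change beyond the scatter is expected in this assay, and neither direction is favoured. The expected step is a 1.1-fold lower number from compound 3 to compound 4 (0.03 log units; within the scatter). For compound 4 the estimated value is 80000 nM, with an expected range from 40000 nM to 160000 nM.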

Compound 4, half-maximal cytotoxic concentration: 61200 nM
The estimate for compound 4 lay 1.3-fold (0.12 log units) above the measured number; the range from low to high includes it.
By their numbers in this assay, from the lowest: compounds 4, 2 and 3 (each within the scatter of the next).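

In this assay, 3-methoxybenzyl in place of 4-fluorobenzyl on the amide-type nitrogen comes with a 1.4-fold lower number from compound 3 to compound 4 (0.15 log units; within the scatter) and so makes no readable difference, even though the ring's substituent changes from fluorine to methoxy and the entering group carries a hydrogen-bond acceptor that the leaving group lacks. The second comparison, 3-methoxybenzyl in place of phenyl at that nitrogen, comes with a 1.1-fold lower number from compound 2 to compound 4 (0.04 log units; within the scatter) and is also too small to read. Compounds 2, 3 and 4 therefore cannot be told apart in this test, so among these three groups the choice at this position has no visible bearing on the number, and no measurement shown gives a reason for that.

Going by these compounds, all three groups tested here end in an aromatic ring with no net charge, so it remains open whether an amine or a carboxylic acid on that ring, or a longer chain between the ring and the amide-type nitrogen, would move the number beyond the scatter. On these data alone, compound 1 has no number, so what happens when the core itself changes, as it does from compound 4 to compound 1, also stays unknown.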